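Lengthening the Chain of Compound 2

This account rests on a few compounds, and the source may have more. Where it says the series, first, only, none or still open, it means among the compounds named here.

In a physicochemical assay for lipophilicity (on this read-out lower numbers stand for lower lipophilicity and higher numbers for higher lipophilicity), compound 1 (`CCNC(=O)c1ccc(S(N)(=O)=O)cc1`) gives 0.03 and compound 2 (`CCCCCNC(=O)c1ccc(S(N)(=O)=O)cc1`) gives 1.54 as the higher of the two numbers. Between them lies the only measured step, a number 1.51 log units higher from compound 1 to compound 2 (beyond the scatter) for propyl in place of hydrogen on a saturated chain carbon, two bonds along the chain from an amide-type nitrogen.

Compound 3 (`CCCCCCCNC(=O)c1ccc(S(N)(=O)=O)cc1`) has not yet been measured. Its difference from compound 2 reads ethyl in place of hydrogen on a saturated chain carbon, five bonds along the chain from an amide-type nitrogen and amounts to ethyl in place of hydrogen on a saturated chain carbon, five bonds along the chain from an amide-type nitrogen. This change also lengthens the chain, though with ethyl rather than propyl, and the data offer one step as a guide. That step, a number 1.51 log units higher from compound 1 to compound 2 (beyond the scatter) for the same kind of extension, suggests a move in the same direction, somewhat smaller but still beyond the scatter. The expected change is a number 1.01 log units higher from compound 2 to compound 3 (beyond the scatter) in this assay for the longer chain. For compound 3 the estimated value is 2.55 and the expected range runs from 2.15 to 2.95 as its two ends.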

Compound 3, partition coefficient: 2.57
Compound 3: middle estimate off by 0.02 log units, on the low side; measured number inside the range.
By their numbers in this assay, from the lowest: compound 1; then compound 2; then compound 3.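

The new result shows that the read-out keeps responding well beyond the chain of compound 2: in this assay, ethyl in place of hydrogen on a saturated chain carbon, five bonds along the chain from an amide-type nitrogen, gives a number 1.03 log units higher from compound 2 to compound 3 (beyond the scatter) and is still a large step at this outer position. Measured from the shortest chain, the whole extension gives a number 2.54 log units higher from compound 1 to compound 3 (beyond the scatter) and the three compounds now rank in the order of their chain length, with none of them going against that order. No independent evidence bears on the origin of these steps.

The compounds shown leave open whether a longer chain than that of compound 3 would raise the number further, or whether the rise would continue in steps of a similar size. They also leave open what a hydroxyl group, an amine or a carboxylic acid in place of hydrogen at this same chain carbon would do to the number, since every change shown here adds only a plain alkyl group.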